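The source may report more compounds than this note shows. Statements on the series, on what has been measured and on what is new or still open speak of the compounds shown alone.

In a physicochemical assay for solubility, measured as kinetic solubility (on this read-out lower numbers stand for lower solubility and higher numbers for higher solubility), compound 1 `O=C(NCc1ccncc1)C1CCN(C(=O)c2cc3ccccc3n2Cc2ccc(Cl)cc2)CC1` gives 31000 nM. Compound 2 `CC(NC(=O)C1CCN(C(=O)c2cc3ccccc3n2Cc2ccc(Cl)cc2)CC1)c1ccncc1` gives 31000 nM, which places it level with compound 1. The next structure, compound 3 `O=C(NCCCc1ccncc1)C1CCN(C(=O)c2cc3ccccc3n2Cc2ccc(Cl)cc2)CC1`, keeps the shared core and differs only in the group on the amide-type nitrogen: 3-(pyridin-4-yl)propyl in place of 1-(pyridin-4-yl)ethyl on an amide-type nitrogen. Within the data shown here, only one measured step bears on this change: no change at the digits printed from compound 1 to compound 2 (within the scatter). That step was a methyl in place of hydrogen on a saturated chain carbon, and it stayed within the scatter. It is a single, smaller edit, so it offers only weak guidance for the swap to 3-(pyridin-4-yl)propyl and points in no direction. No step beyond the scatter is therefore expected in this assay. The estimated step is a 1.2-fold lower number from compound 2 to compound 3 (0.09 log units; within the scatter). The expected value for compound 3 is 25000 nM, within an estimated range of 10000 nM to 50000 nM.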

Compound 3, solubility: 16000 nM
Estimate against measurement, compound 3: 1.6-fold (0.19 log units) above, within the range that was stated.
By their numbers in this assay, from the lowest: compounds 3, 1 and 2 (each within the scatter of the next).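

In this assay, putting 3-(pyridin-4-yl)propyl in place of 1-(pyridin-4-yl)ethyl on the amide-type nitrogen gives a 1.9-fold lower number from compound 2 to compound 3 (0.29 log units; within the scatter), so this larger edit to the chain stays inside the usual scatter, as the small methyl edit did. Read against the simplest chain, 2-(pyridin-4-yl)ethyl in place of pyridin-4-yl on the saturated chain carbon gives a 1.9-fold lower number from compound 1 to compound 3 (0.29 log units; within the scatter), which is also inside the scatter, so these three chains cannot be told apart in this measurement. Nothing available gives a reason for this outcome. From the compounds shown here alone, whether a longer chain than 3-(pyridin-4-yl)propyl would give a step beyond the scatter remains open. So does the effect of an amine or a carboxylic acid in place of the pyridin-4-yl group on that chain.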